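Swapping the fluorinated ring for an ethyl-bearing ring

The source may hold more compounds than are shown below. What is called first, only, known or untested is meant among the compounds shown, and "the series" means these compounds.

Three compounds sharing one core have been run through a functional assay on A549 cells (Homo sapiens) for inhibition, read by CCK-8 assay, with a stated time of 72 h, tested at 8 uM; a lower number here means less inhibition of growth, a higher number more inhibition of growth at the concentration tested. Compound 1 `Nc1ccccc1NC(=O)/C=C/c1ccc(CSc2cccc(F)c2)cc1` gives 56.6% in this assay. Compound 2 `Nc1ccccc1NC(=O)c1ccc(CSc2cccc(F)c2)cc1` gives 72.7%, a higher number than compound 1 by a margin beyond the usual scatter, while compound 3 `COC(=O)c1ccccc1SCc1ccc(C(=O)Nc2ccccc2N)cc1` gives 46.1%, a lower number than compound 1, again beyond the scatter. Compound 1 therefore sits between the other two, the second highest of the three.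

The next compound, compound 4 `CCc1ccc(SCc2ccc(/C=C/C(=O)Nc3ccccc3N)cc2)cc1`, is not yet measured. It differs from compound 1 in one place: 4-ethylphenyl in place of 3-fluorophenyl on a sulfur. Going by the values given here, no measured pair shows this kind of exchange, so there is no direct precedent for how large a step it should bring. The change keeps the same kind of ring on the sulfur and alters neither hydrogen-bond donors nor acceptors. The step from compound 1 to compound 4 is expected to be small, a number 1.6 percentage points lower from compound 1 to compound 4 (within the scatter), within the scatter. Compound 4 is estimated at 55%, with a range from 40% to 70%, because compound 1 stands at 56.6% and nothing in the data argues for a large move.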

Compound 4, percent growth inhibition at one concentration: 68.6%
For compound 4 the middle estimate is 13.6 percentage points below the measured one; the range from low to high includes it.
By their numbers in this assay, from the lowest: compound 3; then compound 1; then compounds 4 and 2 (each within the scatter of the next).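

In this assay putting 4-ethylphenyl in place of 3-fluorophenyl on the sulfur brings a number 12 percentage points higher from compound 1 to compound 4 (beyond the scatter) and so counts as a modest step. This shows that the group on this sulfur can change the result even when the new group is also a six-membered aromatic ring of carbon only and neither group has hydrogen-bond donors or acceptors. Nothing available explains the rise or shows whether gaining the ethyl or losing the fluorine matters more.

A plain phenyl, a 4-methylphenyl or a 4-propylphenyl on the same sulfur could help separate those two parts of the exchange, but the compounds shown leave that open. Also open, going by these compounds, is whether the same exchange on compound 2 would bring a similar step.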